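A few compounds are considered here, and "the series" means these few. Any claim that something is new, unique, unknown or untested is made for them only; others in the source may bear on it.

Of the compounds shown here, two sharing one core have been measured in an assay on cells for inhibition of alkaline phosphatase, tissue-nonspecific isozyme (Homo sapiens), read by luminescence, with stated times of 7 min and 20 min; on this read-out higher numbers stand for weaker inhibition and lower numbers for stronger inhibition. Compound 1 `CN(C)CCNc1nn2c(=O)cc(C(F)(F)F)nc2s1` gives 450 nM, and compound 2 `CCOc1ccccc1-c1nn2c(=O)cc(C(F)(F)F)nc2s1` gives 4520 nM, the higher of the two numbers; its gap to compound 1 lies beyond the usual scatter. Compound 3 `O=c1cc(C(F)(F)F)nc2sc(-c3ccccc3F)nn12` differs from compound 2 in one place: fluoro in place of ethoxy on an aromatic carbon. Within the data shown here, no measured pair shows this step, so its size and direction are open. The step is expected to be small, a 1.1-fold higher number from compound 2 to compound 3 (0.04 log units; within the scatter), within the scatter. Compound 3 is therefore estimated at 5000 nM, within 1500 nM to 20000 nM.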

Compound 3, half-maximal inhibitory concentration: > 100000 nM
Compound 3 gave a limit, no number; the forecaster's own chance of this, stated with the estimate: 15%; middle value at least 20-fold (1.30 log units) away from the limit.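

In this assay compound 3 reads only as a limit, not as a number: the limit of > 100000 nM in this assay, at which 1 of the 3 values shown sits. On an aromatic carbon ortho to a large group, fluoro in place of ethoxy proves no minor swap, giving an at least 22-fold higher number from compound 2 to compound 3 (1.34 log units; beyond the scatter). Placing 2-fluorophenyl where (2-(dimethylamino)ethyl)amino stands gives an at least 220-fold higher number from compound 1 to compound 3 (2.34 log units; beyond the scatter), so the group at this place on the shared core strongly shapes the read-out.

From the compounds shown here alone, the full size of both steps stays open. So does whether a methoxy group, a longer alkoxy chain or an amine in the place of fluoro would restore inhibition.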